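Sulfonyl aryl swap: working notes on compounds 2 and 4

The compounds below may be only part of what the source reports. "The series", "measured", "known", "first", "only" and "open" are said of these compounds alone.

Compound 2 `O=S(=O)(c1ccc(F)c(Cl)c1)c1cnc2cc(F)ccc2c1-c1ccc(Cl)cc1` gives 0.39 mL/min in an ADME assay on microsomes from liver (Homo sapiens) for metabolic stability, tested at 2.5 uM; on this read-out lower numbers stand for slow clearance and higher numbers for fast clearance. Among the three compounds measured, compound 2 stands second highest: compound 1 `O=S(=O)(c1ccc(F)c(F)c1)c1cnc2c(F)cccc2c1-c1ccc(Cl)cc1` gives 0.28 mL/min in this assay, a gap within the usual scatter, while compound 3 `O=S(=O)(c1cc(Cl)cc(Cl)c1)c1cnc2cc(F)ccc2c1-c1ccccc1F` gives 0.93 mL/min in this assay, a clearly higher number, beyond the scatter. Compound 4 `O=S(=O)(c1cc(F)cc(F)c1)c1cnc2cc(F)ccc2c1-c1ccc(Cl)cc1` differs from compound 2 in one place: 3,5-difluorophenyl in place of 3-chloro-4-fluorophenyl on a sulfonyl sulfur. For the measured compounds named here, no measured pair isolates this change, so no step size can be read from the data. The expected step in this assay is a 1.2-fold lower number from compound 2 to compound 4 (0.09 log units; within the scatter), no larger than the usual scatter and in no firm direction. Compound 4 is therefore expected to give 0.32 mL/min in this assay, within a range from 0.15 mL/min to 0.7 mL/min.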

Compound 4, intrinsic clearance in a liver preparation (reported as CLH), per the amount of preparation that the assay uses: 0.03 mL/min
For compound 4 the middle estimate is 11-fold (1.03 log units) above the measured one; measured number below the stated range.
By their numbers in this assay, from the lowest: compound 4; then compounds 1 and 2 (each within the scatter of the next); then compound 3.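

In this assay, for the compounds shown here, 3,5-difluorophenyl in place of 3-chloro-4-fluorophenyl on a sulfonyl sulfur brings a 13-fold lower number from compound 2 to compound 4 (1.11 log units; beyond the scatter), the first step that isolates this position. The read-out therefore responds strongly here, although the heavy-atom count, the ring type and the net charge stay unchanged. Nothing available accounts for the size of this step. Going by these compounds, it remains open whether a pyridyl or a 3-cyanophenyl group on the sulfonyl sulfur would give a similar number. On these data alone, whether the step carries over to the core of compound 1 also remains open.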